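Series notes: nitro for isopropyl on the fused aromatic ring

The source may hold more compounds than are shown below. What is called first, only, known or untested is meant among the compounds shown, and "the series" means these compounds.

Measured so far:
Compound 1 `CN1C(=O)/C(=C/C(=O)OC(C)(C)C)c2ccccc21`: 81.9%
Compound 2 `CC(C)c1ccc2c(c1)/C(=C\C(=O)OC(C)(C)C)C(=O)N2`: 82.8%

Both compounds were read in a functional assay on SAOS-2 cells (Homo sapiens) for inhibition, read by CCK-8 assay, with a stated time of 72 h, tested at 20 uM; on this read-out lower numbers stand for less inhibition of growth and higher numbers for more inhibition of growth at the one concentration tested. Compound 2 stands highest of the two numbers, yet its nearest neighbour, compound 1, lies only a hair lower, a gap that sits within the usual scatter of repeated measurements, so the two compounds cannot be told apart on this read-out. Both carry the same unsaturated ester arm on the shared core and differ in the amide substituent and in the ring substituent, without any visible effect in this assay.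

Compound 3 `CC(C)(C)OC(=O)/C=C1/C(=O)Nc2ccc([N+](=O)[O-])cc21` takes the ring substituent of compound 2 and replaces it: nitro in place of isopropyl on an aromatic carbon. Among the measured compounds shown here, no pair of measured compounds maps this exchange, so nothing tells how far a nitro group moves the number. Given that both measured compounds sit close together in this assay, the step is expected to stay small: the change expected is a number 6.8 percentage points lower from compound 2 to compound 3 (within the scatter), none beyond the scatter. Compound 3 is estimated at 76%, within a range from 55% to 90%.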

Compound 3, percent growth inhibition at one concentration: 82.8%
Estimate against measurement, compound 3: 6.8 percentage points below, within the range that was stated.
By their numbers in this assay, from the lowest: compounds 1, 2 and 3 (each within the scatter of the next).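

In this assay, among the compounds shown here, the exchange of isopropyl for nitro on an aromatic carbon gives no change at the digits printed from compound 2 to compound 3 (within the scatter) and is the first step that can be read at this position. Isopropyl and nitro each hold 3 heavy atoms, but the nitro group has 2 hydrogen-bond acceptors where isopropyl has 0, and this difference leaves no trace in this one pair at the single concentration tested. No available evidence bears on why the number stays in place through this exchange.

Still open, going by these compounds, is whether an amine, a carboxylic acid or a longer chain such as n-butyl on the same aromatic carbon would also leave the number in place, which would show how much this position tolerates beyond these two groups. Also open, on these data alone, is whether nitro and isopropyl stay level on the core of compound 1, which carries a methyl group in place of the amide hydrogen.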